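Ethyl to methyl in a weakly active series

The compounds below may be only part of what the source reports. "The series", "measured", "known", "first", "only" and "open" are said of these compounds alone.

Within the data shown here, in a functional assay on MCF7 cells (Homo sapiens) for inhibition (a lower number here means a stronger inhibitor, a higher number a weaker inhibitor), compound 2 `CCN(CC)CCNC(=O)CC(CC(=O)N(CC)C1Cc2ccccc2C1)c1ccc(Cl)cc1` gives 23000 nM, the only actual number so far. Compound 1 `CCN(CC)CCNC(=O)CC(CC(=O)N(C)C1Cc2ccccc2C1)c1ccccc1` gives > 100000 nM, which is a limit of the assay and not a number.

Compound 3 `CCN(CC)CCNC(=O)CC(CC(=O)N(C)C1Cc2ccccc2C1)c1ccc(Cl)cc1` is the unmeasured neighbour of compound 2. The change is hydrogen in place of methyl on a saturated chain carbon bound to an amide-type nitrogen, so that ethyl becomes methyl. Among the measured compounds shown here, compound 1 differs from compound 2 in more than one place, so no measured step isolates this change.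

A small loss of potency in this assay is expected, and it may not exceed the usual scatter. The estimated change is a 1.7-fold higher number from compound 2 to compound 3 (0.24 log units; within the scatter). For compound 3 the expected value is 40000 nM, with an estimated range from 15000 nM to 100000 nM.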

Compound 3, half-maximal inhibitory concentration: 28800 nM
The estimate for compound 3 lay 1.4-fold (0.14 log units) above the measured number; low and high end bracket the measured number.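

On the saturated chain carbon bound to an amide-type nitrogen, the replacement of ethyl by methyl now has a measured size in this assay: a 1.3-fold higher number from compound 2 to compound 3 (0.10 log units; within the scatter). Among these compounds, compound 3 also isolates chloro in place of hydrogen on an aromatic carbon, a change that no earlier pair showed on its own: an at least 3.4-fold lower number from compound 1 to compound 3 (0.54 log units; beyond the scatter). Compound 1 stands at a limit of the assay and not at a number, so this step is only a bound: the limit of > 100000 nM in this assay, at which 1 of the 3 values shown sits.

On these data alone, whether a longer chain such as propyl on that amide-type nitrogen would move the number beyond the scatter remains open. Also open, as far as these compounds go, are the true size of the chloro step and whether bromo or methoxy on the same aromatic carbon would give a similar result.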